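This account rests on a few compounds, and the source may have more. Where it says the series, first, only, none or still open, it means among the compounds named here.

Compound 1 `CCCS(=O)(=O)N1CCN(c2ccc(OCC3CCN(C(=O)CC(C)C)CC3)cn2)CC1` carries an isobutyl group on a carbonyl carbon; in a functional assay on CHO-K1 cells for agonist activity at Glucose-dependent insulinotropic receptor (Homo sapiens), read by a luciferase reporter, with a stated time of 5 h (a lower number here means that less compound is needed, a higher number that more compound is needed for the effect), compound 1 gives 1600 nM. Compound 2 `CCCS(=O)(=O)N1CCN(c2ccc(OCC3CCN(C(=O)NC(C)(C)C)CC3)cn2)CC1` has tert-butylamino in that place, and compound 2 gives 800 nM, so that a 2.0-fold lower number from compound 1 to compound 2 (0.30 log units; within the scatter). Compound 3 `CCCS(=O)(=O)N1CCN(c2ccc(OCC3CCN(C(=O)NC4CCCCC4)CC3)cn2)CC1` has cyclohexylamino on the same carbon. For compound 3 the assay reports only a limit, > 10000 nM, not a number. Compound 3 therefore stands at the high end of the set, with an at least 6.2-fold higher number from compound 1 to compound 3 (0.79 log units; beyond the scatter) and an at least 12-fold higher number from compound 2 to compound 3 (1.09 log units; beyond the scatter), both beyond the scatter. Compound 4 `CCCS(=O)(=O)N1CCN(c2ccc(OCC3CCN(C(=O)C(F)F)CC3)cn2)CC1` follows with the change (difluoromethyl in place of cyclohexylamino on a carbonyl carbon). The two measured steps into compound 3 bear on this: the cyclohexylamino group gives the worst numbers seen, while the smaller isobutyl and tert-butylamino groups of compounds 1 and 2 give numbers well inside the measured range. Among the compounds with values here, compound 4 carries a group smaller than either of those, so a return toward the numbers of compounds 1 and 2 is expected, though no measured compound tells how difluoromethyl itself behaves here. The step expected is an at least 5.0-fold lower number from compound 3 to compound 4 (0.69 log units; beyond the scatter). Compound 4 is estimated at 2000 nM, with a range from 600 nM to 7000 nM.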

Compound 4, half-maximal effective concentration: 2100 nM
For compound 4 the middle estimate is 1.1-fold (0.02 log units) below the measured one, and the stated range covers the measured number.
By their numbers in this assay, from the lowest: compounds 2, 1 and 4 (each within the scatter of the next, the first and the last beyond it). At a limit, above all of these: compound 3.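

Replacing cyclohexylamino with difluoromethyl on this carbonyl carbon gives an at least 4.7-fold lower number from compound 3 to compound 4 (0.67 log units; beyond the scatter), so a group of 3 heavy atoms with no ring does not share the poor result of the 7-atom cyclohexylamino group. Against the other groups, the change gives a 1.3-fold higher number from compound 1 to compound 4 (0.12 log units; within the scatter) from isobutyl and a 2.6-fold higher number from compound 2 to compound 4 (0.42 log units; beyond the scatter) from tert-butylamino, so difluoromethyl cannot be told apart from isobutyl, yet it is the first group here to separate from tert-butylamino by more than the scatter, even though isobutyl does not. The first step has only a bound, as compound 3 stands at a limit and not at a number: the limit of > 10000 nM in this assay, at which 1 of the 4 values shown sits.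

The compounds shown leave open whether the ring of cyclohexylamino or simply its size goes with the result for compound 3, a question that a cyclopentylamino group or an open-chain hexylamino group at this place would address. As far as these compounds go, they also do not show how methyl or trifluoromethyl on the same carbonyl carbon compares with difluoromethyl, so the part played by the fluorine atoms remains unknown.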